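A few compounds are considered here, and "the series" means these few. Any claim that something is new, unique, unknown or untested is made for them only; others in the source may bear on it.

Measured in a functional assay on CCRF-CEM cells (Homo sapiens) for cytotoxicity, in the presence of a further agent that is not named here; a higher number here means a weaker inhibitor, a lower number a stronger inhibitor:
- compound 1 `COC(=O)c1ccc(CN(CCCc2c(N)nc(N)nc2O)c2cc(F)cc(F)c2[N+](=O)[O-])cc1`: > 100000 nM
- compound 2 `Nc1nc(N)c(CCCN(Cc2ccc(NC(CCC(=O)O)C(=O)O)cc2)c2cc(F)cc(F)c2[N+](=O)[O-])c(O)n1`: > 100000 nM

The value of compound 1, > 100000 nM, is a limit and not a number. The value of compound 2, > 100000 nM, is likewise a limit. So compound 1 can be placed only at that limit, and the values shown do not rank it against compound 2.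

Compound 3 `COC(=O)c1ccc(CN(CCCc2c(N)nc(N)nc2O)c2ccc([N+](=O)[O-])c(F)c2F)cc1` has the same atoms as compound 1, joined differently: 2,3-difluoro-4-nitrophenyl in place of 3,5-difluoro-2-nitrophenyl on an amine nitrogen. Within the data shown here, the one measured step, a step that the two limits leave unreadable from compound 1 to compound 2, changes a different group and has no readable size, so it offers no size to carry over. Among the measured compounds shown here, the only guide is the limit of > 100000 nM in this assay, at which 2 of the 2 values shown sit. No step beyond the scatter, in either direction, is therefore expected in this assay.

The estimated a number no higher from compound 1 to compound 3 (the limit leaves the size open) is accordingly no real change. Compound 3 is expected to give about 100000 nM, with an expected range of 30000 nM to 200000 nM.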

Compound 3, half-maximal inhibitory concentration: 45000 nM
Compound 3: the middle estimate sits 2.2-fold (0.35 log units) above what was measured, and the stated range covers the measured number.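

In this assay, among these compounds, the same atoms joined differently, with 2,3-difluoro-4-nitrophenyl in place of 3,5-difluoro-2-nitrophenyl on the amine nitrogen, give an at least 2.2-fold lower number from compound 1 to compound 3 (0.34 log units; beyond the scatter) and so the first real number of the series rather than a limit. This shows that the arrangement of the fluorines and the nitro group on this aromatic ring can change the result, something the earlier pair could not show, as the step between those two compounds cannot be read. The size of the new step is only a lower bound, and most of the series still sits at the limit: the limit of > 100000 nM in this assay, at which 2 of the 3 values shown sit.

Still open, going by these compounds, is whether a different group at this place, such as plain phenyl or a chlorophenyl, would lower the number further. Also open, on these data alone, is how 2,3-difluoro-4-nitrophenyl behaves when the methoxycarbonyl is replaced by a carboxylic acid or by the (1,3-dicarboxypropyl)amino group of compound 2.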